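Dropping a Methoxy Group from Compound 2

The source may report more compounds than this note shows. Statements on the series, on what has been measured and on what is new or still open speak of the compounds shown alone.

Of the compounds shown here, two have been measured in an assay on isolated protein for inhibition of Retinaldehyde dehydrogenase 3 (Homo sapiens); on this read-out higher numbers stand for weaker inhibition and lower numbers for stronger inhibition. Compound 1 `C[C@@H](Sc1nc2c(cnn2C)c(=O)n1-c1ccccc1)c1ccccc1` gives 34 nM. Compound 2 `COc1ccccc1C(C)Sc1nc2c(cnn2C)c(=O)n1-c1ccccc1`, which carries a methoxy group on one phenyl ring, gives 112 nM. Compound 2 thus stands at the highest, that is the weakest, of the two numbers, and its gap to compound 1 lies beyond the usual scatter.

Compound 3 `CC(Sc1nc2c(cnn2C)c(=O)n1-c1ccccc1)c1ccccc1` is the next compound to be measured in this assay. It differs from compound 2 by hydrogen in place of methoxy on an aromatic carbon. Among the measured compounds shown here, no measured pair shows this exact change on its own, so the expected size of the step has to be judged from what is known. Compound 1, which also carries a plain phenyl ring at the same place, gives 34 nM in this assay, a clearly lower number than compound 2. On that basis the move from compound 2 to compound 3 is expected to lower the number, by a step of roughly a 2.2-fold lower number from compound 2 to compound 3 (0.35 log units; beyond the scatter), meaning a gain in potency that is more likely than not to reach beyond the scatter. Compound 3 is therefore estimated to give 50 nM in this assay, with a likely range from 25 nM to 120 nM.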

Compound 3, half-maximal inhibitory concentration: 73 nM
For compound 3 the middle estimate is 1.5-fold (0.16 log units) below the measured one; the range from low to high includes it.
By their numbers in this assay, from the lowest: compound 1; then compounds 3 and 2 (each within the scatter of the next).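

Taking the methoxy group away, the change from 2-methoxyphenyl to phenyl, moves the reading in this assay only by a 1.5-fold lower number from compound 2 to compound 3 (0.19 log units; within the scatter) and so cannot be told apart from repeat-measurement noise. Among the compounds shown here, this is the first direct look at this change, and on these two compounds the methoxy group at this aromatic carbon neither clearly helps nor clearly harms inhibition. The clearer difference appears where no atom changes at all, in a 2.1-fold higher number from compound 1 to compound 3 (0.33 log units; beyond the scatter) and the only thing that separates this pair is how the saturated chain carbon is drawn, so the gap goes with the stereo drawing and not with any group: the fact that one of compounds 1 and 3 is drawn with a defined configuration and the other without, at the place where they differ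

Still open, as far as these compounds go, is how the mirror-image form of compound 1 would read, and whether compound 2 drawn as a single defined form would stay as close to its hydrogen counterpart. Also open, from the compounds shown here alone, is whether an amine or a carboxylic acid on the same aromatic carbon would move the number further than methoxy does, or whether methoxy placed elsewhere on the ring would matter more.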